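Phenoxymethyl variations on a pyrazole benzamide series

The compounds below may be only part of what the source reports. "The series", "measured", "known", "first", "only" and "open" are said of these compounds alone.

Measured so far:
- compound 1 `CNC(=O)c1cccc(Cn2nc(C)c(NC(=O)c3ccc(COC4CCCCC4)cc3)c2C)c1`: 14000 nM
- compound 2 `CNC(=O)c1cccc(Cn2nc(C)c(NC(=O)c3ccc(COc4ccc(C)cc4)cc3)c2C)c1`: 2600 nM
- compound 3 `CNC(=O)c1cccc(Cn2nc(C)c(NC(=O)c3ccc(COc4ccc(OC)cc4)cc3)c2C)c1`: 8000 nM

All three share one core and differ only in the group on the oxygen on a saturated carbon. In a functional assay on MIA PaCa-2 cells (Homo sapiens) for antiproliferative activity, read by MTT assay, with a stated time of 72 h (on this read-out lower numbers stand for an effect already at smaller amounts and higher numbers for an effect only at larger amounts of compound), compound 3 gives 8000 nM and stands second highest of the three numbers; one of its two gaps is a 1.8-fold lower number from compound 1 to compound 3 (0.24 log units; within the scatter), which lies within the scatter, while the other is a 3.1-fold higher number from compound 2 to compound 3 (0.49 log units; beyond the scatter), beyond the scatter.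

Compound 4 `CNC(=O)c1cccc(Cn2nc(C)c(NC(=O)c3ccc(COc4ccccc4Cl)cc3)c2C)c1` is not yet measured. Against compound 3 the change is 2-chlorophenyl in place of 4-methoxyphenyl on an oxygen on a saturated carbon.

The step that bears most on this is a 3.1-fold higher number from compound 2 to compound 3 (0.49 log units; beyond the scatter): replacing a methyl by a methoxy on the aromatic ring raised the number. Going by the values given here, compound 4 removes the methoxy altogether, but no measured step tests a chlorine or a substituent in this place on the ring, so the direction rests on that single comparison. A modest lowering is expected, a 2.0-fold lower number from compound 3 to compound 4 (0.30 log units; within the scatter), with a wide range because only a 3.1-fold higher number from compound 2 to compound 3 (0.49 log units; beyond the scatter) is available as a guide. Compound 4 is estimated at 4000 nM, between 1500 nM and 12000 nM.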

Compound 4, half-maximal effective concentration: 6300 nM
Compound 4: middle estimate off by 1.6-fold (0.20 log units), on the low side; the range from low to high includes it.
By their numbers in this assay, from the lowest: compound 2; then compounds 4, 3 and 1 (each within the scatter of the next, the first and the last beyond it).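

In this assay, 2-chlorophenyl in place of 4-methoxyphenyl gives a 1.3-fold lower number from compound 3 to compound 4 (0.10 log units; within the scatter) and so cannot be told apart from 4-methoxyphenyl at this position. Unlike 4-methoxyphenyl, 2-chlorophenyl separates from cyclohexyl on the oxygen on a saturated carbon, with a 2.2-fold lower number from compound 1 to compound 4 (0.35 log units; beyond the scatter) as the step, while a 2.4-fold higher number from compound 2 to compound 4 (0.38 log units; beyond the scatter) keeps 4-methylphenyl as the group giving the lowest number of the four. No measurement at hand accounts for these gaps.

2-chlorophenyl and 4-methylphenyl differ in both the substituent and its place on the ring, so the two contributions to their gap cannot be separated. Also open, going by these compounds, is how a plain phenyl group, or an amine or a carboxylic acid on that ring, would read in this assay and whether any substituent is needed at all.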